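A few compounds are considered here, and "the series" means these few. Any claim that something is new, unique, unknown or untested is made for them only; others in the source may bear on it.

Measured values, from a functional assay on HT-29 cells (Homo sapiens) for cytotoxicity, read by MTT assay, with a stated time of 24 h; on this read-out higher numbers stand for weaker inhibition and lower numbers for stronger inhibition:
- compound 1, `Clc1ccc(-c2nnc(C(NCc3ccccc3)c3ccc[nH]3)o2)cc1` — 54500 nM
- compound 2, `Clc1ccc(-c2nnc(C(NCc3ccccc3)c3ccc[nH]3)o2)cc1Cl` — 41700 nM
- compound 3, `COc1ccc(CNC(c2ccc[nH]2)c2nnc(-c3ccccc3)o2)cc1` — 286000 nM

Compound 3 carries the highest number of the three; the difference between its core and that of compound 1 is not broken down here. For the measured compounds named here, the one change that recurs is chloro in place of hydrogen on an aromatic carbon, which produced a 1.3-fold lower number from compound 1 to compound 2 (0.12 log units; within the scatter). Compound 4, `COc1ccc(CNC(c2ccc[nH]2)c2nnc(-c3cccc(Cl)c3)o2)cc1`, is not yet measured; it arises from compound 3 by chloro in place of hydrogen on an aromatic carbon. The place differs: in compound 2 the entering chloro sits ortho to a chloro group, in compound 4 it does not, so this is the same kind of change rather than the same one. The expectation in this assay is a step of similar size to a 1.3-fold lower number from compound 1 to compound 2 (0.12 log units; within the scatter), namely a 1.2-fold lower number from compound 3 to compound 4 (0.09 log units; within the scatter), resting on that single earlier step. Compound 4 is therefore estimated at 230000 nM, between 100000 nM and 500000 nM.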

Compound 4, half-maximal inhibitory concentration: 95600 nM
Beside the measured number, compound 4's estimate is 2.4-fold (0.38 log units) above it, and the stated range ends above it.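

In this assay, chloro in place of hydrogen on an aromatic carbon gives a 3.0-fold lower number from compound 3 to compound 4 (0.48 log units; beyond the scatter), and the steps on the two cores cannot be told apart: the same change on two cores in this assay, a 1.3-fold lower number (0.12 log units; within the scatter) from compound 1 to compound 2 and a 3.0-fold lower number (0.48 log units; beyond the scatter) from compound 3 to compound 4, 2.3-fold (0.36 log units) apart, within the scatter of two such steps The change therefore carries to the core of compound 3 with no measurable difference in step size, and in both pairs the number falls or stays within the scatter rather than rising. For the compounds shown here, this does not establish a constant step across the series, since it rests on only two pairs, only one of those steps lies beyond the scatter, and the entering chloro does not stand in the same place in both.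

On these data alone, whether other groups in that place, such as a nitrile, an amine or a carboxylic acid, give steps of like size remains open. Also open, as far as these compounds go, is how chloro behaves on cores other than these two.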